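From 2-methylphenyl to 6-methoxypyridin-3-yl

The source may hold more compounds than are shown below. What is called first, only, known or untested is meant among the compounds shown, and "the series" means these compounds.

In an ADME assay on microsomes from liver (Homo sapiens), read by LC-MS, using NADPH, with a stated time of 10 min, tested at 0.5 uM (a higher number here means that more of the compound is left, a lower number that less of the compound is left), compound 1 `Cc1nc2cc(-c3cccc(Oc4ccccc4)c3)nn2c(-c2cc(F)c3c(c2C)CCCO3)c1C(OC(C)(C)C)C(=O)O` gives 100% and compound 2 `Cc1ccccc1-c1cccc(-c2cc3nc(C)c([C@H](OC(C)(C)C)C(=O)O)c(-c4cc(F)c5c(c4C)CCCO5)n3n2)c1` gives 95% so these two values lie within the scatter of each other. Compound 3 `COc1ccc(-c2cccc(-c3cc4nc(C)c([C@H](OC(C)(C)C)C(=O)O)c(-c5cc(F)c6c(c5C)CCCO6)n4n3)c2)cn1` carries 6-methoxypyridin-3-yl in place of 2-methylphenyl on an aromatic carbon. For the measured compounds named here, no measured pair shows a single change in one place, so the expectation rests on these two values alone. The estimated step of a number 5 percentage points lower from compound 2 to compound 3 (within the scatter) is small and downward, and none beyond the scatter is expected. For compound 3 an estimated 90% is expected in this assay with 75% to 100% as its range.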

Compound 3, percent of the compound remaining: 73%
Compound 3: middle estimate off by 17 percentage points, on the high side, outside the stated range (below it).
By their numbers in this assay, from the lowest: compound 3; then compounds 2 and 1 (each within the scatter of the next).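

For the compounds shown here, at this position, on an aromatic carbon meta to a large group, the aryl substituent is not neutral in this assay as 6-methoxypyridin-3-yl in place of 2-methylphenyl gives a number 22 percentage points lower from compound 2 to compound 3 (beyond the scatter) and is the only step on hand beyond the scatter. The entering group differs in both its ring nitrogen and its methoxy, so the step cannot be assigned to either one. No measurement available explains the drop. Open, from the compounds shown here alone, is whether a pyridin-3-yl without the methoxy or a methoxyphenyl group would retain more compound, which would separate these two contributions.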